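The source may report more compounds than this note shows. Statements on the series, on what has been measured and on what is new or still open speak of the compounds shown alone.

Measured so far in a functional assay on BV-2 cells (Mus musculus) for inhibition, read by Griess assay, with stated times of 3 h and 24 h; a lower number here means a stronger inhibitor, a higher number a weaker inhibitor:

- compound 3, `[O-][S+](/C=C/c1ccc(O)c(O)c1)Cc1ccc(Cl)cc1`, gives 14000 nM
- compound 1, `O=S(=O)(/C=C/c1ccc(O)c(O)c1)CCc1ccccc1`, gives 30600 nM
- compound 2, `[O-][S+](/C=C/c1ccc(O)c(O)c1)Cc1ccccc1`, gives 50300 nM

Compound 3 stands lowest of the three numbers in this assay. Its nearest neighbour is compound 1, whose number is higher by a margin beyond the scatter, and the furthest is compound 2. Among the measured compounds shown here, the one single-point step among the measured compounds leads from compound 2 to compound 3: a 3.6-fold lower number from compound 2 to compound 3 (0.56 log units; beyond the scatter).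

Compound 4, `CC(C)(C)c1ccc(C[S+]([O-])/C=C/c2ccc(O)c(O)c2)cc1`, is the next compound in line and has not yet been measured in this assay. It differs from compound 3 in one place: tert-butyl in place of chloro on an aromatic carbon, para to a large group. For the measured compounds named here, the only step that bears on this change is the one from compound 2 to compound 3, where a substituent entering at the same place gave a modest, beyond-the-scatter drop in the number. Nothing in the measured set shows what exchanging one such substituent for another does there, so the expectation rests on that single step alone.

On this basis, compound 4 is expected to land near compound 3 or somewhat lower, an expected step of a 1.4-fold lower number from compound 3 to compound 4 (0.15 log units; within the scatter), likely within the scatter. The estimate for compound 4 in this assay is 10000 nM, with a range from 3500 nM to 40000 nM.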

Compound 4, half-maximal inhibitory concentration: 9300 nM
Beside the measured number, compound 4's estimate is 1.1-fold (0.03 log units) above it, and the stated range covers the measured number.
By their numbers in this assay, from the lowest: compounds 4 and 3 (each within the scatter of the next); then compounds 1 and 2 (each within the scatter of the next).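

In this assay, the place on the aromatic ring para to a large group accepts tert-butyl as well as chloro: a 1.5-fold lower number from compound 3 to compound 4 (0.18 log units; within the scatter) stays within the scatter, even though tert-butyl brings 4 heavy atoms where chloro brings 1. Measured against hydrogen at the same place, tert-butyl gives a 5.4-fold lower number from compound 2 to compound 4 (0.73 log units; beyond the scatter), beyond the scatter, so the drop first seen with chloro now appears with a second, quite different substituent, and neither of these two goes against it. No data given here explain why the two substituents cannot be told apart in this assay.

On these data alone, both groups carry no hydrogen-bond donors or acceptors, so it remains open whether an amine, a carboxylic acid or a methoxy group at this place would also give a number close to those of compound 3 and compound 4. As far as these compounds go, it is equally open whether chloro or tert-butyl at the matching place on the longer chain of compound 1 would have any comparable effect there.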